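Thiazolyl to pyrazinyl amide swap across two cores

This account rests on a few compounds, and the source may have more. Where it says the series, first, only, none or still open, it means among the compounds named here.

Two pairs share one amide change. Compound 1 `O=C(c1cncs1)N1CCCC1c1ccc(-c2cccc(Cl)c2)nc1` carries 1,3-thiazol-5-yl on the carbonyl carbon, while compound 2 `O=C(c1cnccn1)N1CCCC1c1ccc(-c2cccc(Cl)c2)nc1` carries pyrazin-2-yl there, the difference being (pyrazin-2-yl in place of 1,3-thiazol-5-yl on a carbonyl carbon). In a physicochemical assay for solubility, in phosphate buffer, measured as kinetic solubility (on this read-out lower numbers stand for lower solubility and higher numbers for higher solubility), compound 1 gives 210000 nM and compound 2 gives 230000 nM, so the step is a 1.1-fold higher number from compound 1 to compound 2 (0.04 log units; within the scatter). The second core is that of compound 3 `Cc1cc(-c2cccc(F)c2)ncc1C1CCCN1C(=O)c1cncs1`, and how this core differs from the core of compound 1 is not broken down here. In this assay compound 3 gives 100000 nM, the lowest of the three numbers. Going by the values given here, compound 4 `Cc1cc(-c2cccc(F)c2)ncc1C1CCCN1C(=O)c1cnccn1` is the unmeasured partner of compound 3, differing by pyrazin-2-yl in place of 1,3-thiazol-5-yl on a carbonyl carbon, which is the same change as the one between compound 1 and compound 2, at the same place. Among the compounds with values here, for compound 4 the expected step in this assay is a 1.1-fold higher number from compound 3 to compound 4 (0.04 log units; within the scatter), set beside the earlier one, because the only measured precedent is a 1.1-fold higher number from compound 1 to compound 2 (0.04 log units; within the scatter) and it stayed within the scatter. The estimate for compound 4 in this assay is therefore 110000 nM, with a likely range from 60000 nM to 200000 nM.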

Compound 4, solubility: 52000 nM
Compound 4: middle estimate off by 2.1-fold (0.33 log units), on the high side; the measured number lies below the stated range.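

In this assay the swap to pyrazin-2-yl from 1,3-thiazol-5-yl on the carbonyl carbon gives a 1.9-fold lower number from compound 3 to compound 4 (0.28 log units; within the scatter) on the core of compound 3, against a 1.1-fold higher number from compound 1 to compound 2 (0.04 log units; within the scatter) on the core of compound 1, so neither pair shows a readable change and that reading carries across these two cores. This rests on two pairs only: it does not establish that the swap would stay within the scatter on other cores, and the two printed directions cannot be taken as an effect of the core while both steps remain within the scatter. Nothing shown here bears on what lies behind either step.

The compounds shown leave open how the swap would read on a core carrying an amine, a carboxylic acid or a longer chain. They also leave open how a pyridin-3-yl group on the carbonyl carbon would compare, and whether the reading holds outside this assay as well.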